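A few compounds are considered here, and "the series" means these few. Any claim that something is new, unique, unknown or untested is made for them only; others in the source may bear on it.

Series notes, aromatic amine substituent on the shared core.

Compound 1 `CCCCOc1cccc(Nc2nc3nonc3nc2O)c1` carries a butoxy group on its aromatic ring. In an assay on mitochondria from L6 cells (Rattus norvegicus) for activation, with a stated time of 90 min (a higher number here means that more compound is needed for the effect, a lower number that less compound is needed), compound 1 gives 2300 nM. For the measured compounds named here, the only other measured member is compound 2 `Oc1nc2nonc2nc1Nc1ccc(S(F)(F)(F)(F)F)cc1`, which in this assay gives 3900 nM. Going by the values given here, compound 1 thus has the lowest of the two numbers so far, but its nearest neighbour compound 2 sits within the usual scatter, so the two values cannot be ordered.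

Compound 3 `Oc1nc2nonc2nc1Nc1cccc(F)c1` is not yet measured. Against compound 1 the change is fluoro in place of butoxy on an aromatic carbon; the butoxy group leaves and a single fluorine enters at the same aromatic carbon. Among the compounds with values here, no step between measured compounds bears on this change, and the two measured values, from structures that differ in several places, lie within the scatter of each other.

The expectation for the step from compound 1 to compound 3 in this assay is a modest move toward a higher number, a 1.7-fold higher number from compound 1 to compound 3 (0.24 log units; within the scatter), which may not exceed the scatter. Compound 3 is therefore estimated at 4000 nM in this assay, with a range from 1500 nM to 12000 nM.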

Compound 3, half-maximal effective concentration: 31200 nM
Estimate against measurement, compound 3: 7.8-fold (0.89 log units) below, and the stated range ends below it.
By their numbers in this assay, from the lowest: compounds 1 and 2 (each within the scatter of the next); then compound 3.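

For the compounds shown here, on the aromatic carbon meta to a large group, the choice of substituent carries a large effect in this assay: fluoro in place of butoxy gives a 14-fold higher number from compound 1 to compound 3 (1.13 log units; beyond the scatter), the first one-place step and one that lies beyond the scatter. The earlier values could not be ordered and offered no direct comparison at this carbon, whereas this single exchange shows that a lone fluorine does not preserve the lower number seen with the butoxy group. Going by these compounds alone, the compounds measured so far offer no measurement that accounts for the size of this step.

The compounds shown leave open whether the number depends on the length of the chain, on its oxygen, or simply on having more than a single atom at this carbon; methoxy, a longer chain such as hexyloxy, or a plain butyl group would begin to separate these readings. They also leave open whether a polar group on the same carbon, such as an amine or a carboxylic acid, would stay near compound 1 or move toward compound 3.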